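This account rests on a few compounds, and the source may have more. Where it says the series, first, only, none or still open, it means among the compounds named here.

The series rests on a shared core carrying a trimethoxyphenyl group, tested in a functional assay on HL-60 cells (Homo sapiens) for antiproliferative activity, read by MTT assay, with a stated time of 72 h; a lower number here means a stronger inhibitor, a higher number a weaker inhibitor. Compound 1 , `COc1cc(-c2ncnn2-c2ccccc2)cc(OC)c1OC`, is the parent of the step followed here. In this assay compound 1 gives > 10000 nM, which is a limit of the assay and not a number. Compound 2 , `COc1cc(-n2ncnc2-c2cccc(Cl)c2)cc(OC)c1OC`, likewise reaches only a limit in this assay, > 10000 nM. Compound 3 , `COc1cc(-n2ncnc2-c2ccc(OC(F)(F)F)cc2)cc(OC)c1OC`, also returns only a limit in this assay, > 10000 nM. Thus compound 1 sits at the limit of > 10000 nM in this assay, at which 3 of the 3 values shown sit, and nothing among the measured compounds shows a value inside the range of the assay.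

Compound 4 , `COc1cc(-c2ncnn2-c2cccc(F)c2)cc(OC)c1OC`, differs from compound 1 in one place: fluoro in place of hydrogen on an aromatic carbon. Within the data shown here, with every measured compound resting at the limit, no measured step gives a size to expect. The step from compound 1 to compound 4 is expected to be small, a step that the limit leaves unreadable from compound 1 to compound 4, with no direction beyond the scatter. Compound 4 is therefore expected to give about 15000 nM in this assay, between 5000 nM and 50000 nM, most likely again as a limit only.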

Compound 4, half-maximal inhibitory concentration: > 10000 nM
Compound 4 gave a limit, no number; the forecaster's own chance of this, stated with the estimate: 80%; the middle value does not contradict the limit.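

No step can be read from compound 1 to compound 4, because both rest at a limit and not at a number in this assay: the limit of > 10000 nM in this assay, at which 4 of the 4 values shown sit. The compounds shown leave open whether any change on the shared core brings a value inside the range of this assay.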